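The source may hold more compounds than are shown below. What is called first, only, known or untested is meant among the compounds shown, and "the series" means these compounds.

Measured compounds:
compound 1, `COc1ccc(F)cc1CNCCCNc1ccnc2cc(C3CCCCC3)ccc12`, 4200 nM
compound 2, `c1coc(CNCCCNc2ccnc3cc(-c4cccc5ccccc45)ccc23)c1`, 32000 nM

In a physicochemical assay for solubility, with a stated time of 18 h, at pH 7.4 (on this read-out lower numbers stand for lower solubility and higher numbers for higher solubility), compound 1 gives the lowest of the two numbers; the nearest, compound 2, stands higher, beyond the scatter. Compound 3, `COc1ccc(F)cc1CNCCCNc1ccnc2cc(-c3ccc(C(F)(F)F)cc3)ccc12`, has yet to be measured. It differs from compound 1 in one place: 4-(trifluoromethyl)phenyl in place of cyclohexyl on an aromatic carbon. Among the measured compounds shown here, no step between measured compounds is available for this change. A small downward step, not clearly beyond the scatter, is expected: a 1.7-fold lower number from compound 1 to compound 3 (0.23 log units; within the scatter). Compound 3 is therefore estimated at 2500 nM, within a range from 800 nM to 8000 nM.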

Compound 3, solubility: 32000 nM
Compound 3: middle estimate off by 13-fold (1.11 log units), on the low side; measured number above the stated range.
By their numbers in this assay, from the lowest: compound 1; then compounds 2 and 3 (each within the scatter of the next).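

In this assay, among the compounds shown here, 4-(trifluoromethyl)phenyl in place of cyclohexyl on this aromatic carbon gives a 7.6-fold higher number from compound 1 to compound 3 (0.88 log units; beyond the scatter), the first comparison at this position that changes one place only. The step lies beyond the scatter, so with the rest of compound 1 held fixed, the group on this carbon does shift the read-out. Nothing measured here bears on what lies behind the step. On these data alone, whether plain phenyl, or a phenyl carrying an amine or a carboxylic acid, would stand nearer compound 1 or compound 3 remains open. So does whether this change gives a similar step when the rest of compound 1 is altered.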